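This account rests on a few compounds, and the source may have more. Where it says the series, first, only, none or still open, it means among the compounds named here.

Series notes. Compound 1 `Cc1ccc(Oc2ccc(CC3SC(=O)NC3=O)cc2)cc1` gives 547 nM in a functional assay for agonist activity at Free fatty acid receptor 1 (Homo sapiens), read by FLIPR, in the presence of a further agent that is not named here; on this read-out higher numbers stand for an effect only at larger amounts of compound and lower numbers for an effect already at smaller amounts. Within the data shown here, compound 2 `Cc1cccc(Oc2ccc(CC3SC(=O)NC3=O)cc2)n1` gives 2620 nM in this assay, the higher of the two numbers so far; the step from compound 1 to compound 2 was a 4.8-fold higher number from compound 1 to compound 2 (0.68 log units; beyond the scatter), a modest rise on exchange of the oxygen-linked ring.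

Compound 3 `Cc1cccc(Oc2ccc(CC3SC(=O)NC3=O)cc2)c1` differs from compound 2 by 3-methylphenyl in place of 6-methylpyridin-2-yl on an oxygen on an aromatic ring. Among the measured compounds shown here, the only measured step that bears on this change is the reverse one, from compound 1 to compound 2 a 4.8-fold higher number from compound 1 to compound 2 (0.68 log units; beyond the scatter), which also swapped the carbon-only ring against the one-nitrogen ring, though there the methyl stood as 4-methylphenyl rather than 3-methylphenyl. That step suggests the return to a carbon-only ring should lower the number, by roughly the same modest amount, in this assay. For compound 3 the expected value is therefore 700 nM, within a range of 250 nM to 2000 nM, meaning an estimated step of a 3.7-fold lower number from compound 2 to compound 3 (0.57 log units; beyond the scatter). On these data alone, compound 1 stays the only comparator, so the position of the methyl remains untested.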

Compound 3, half-maximal effective concentration: 203 nM
The estimate for compound 3 lay 3.4-fold (0.54 log units) above the measured number; the measured number lies below the stated range.
By their numbers in this assay, from the lowest: compound 3; then compound 1; then compound 2.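

In this assay, the exchange of 6-methylpyridin-2-yl for 3-methylphenyl on the oxygen gives a 13-fold lower number from compound 2 to compound 3 (1.11 log units; beyond the scatter), a large step that shows the one-nitrogen ring can cost more than the earlier comparison with 4-methylphenyl suggested. Among these compounds, the exchange of 4-methylphenyl for 3-methylphenyl gives a 2.7-fold lower number from compound 1 to compound 3 (0.43 log units; beyond the scatter), so the choice between these two methylphenyl groups also changes the number, which the earlier compounds could not show. No supporting data explain either step.

Still open, on these data alone, is how a methoxy group or a chlorine atom in place of the methyl, or an unsubstituted phenyl ring, would read at this position. As far as these compounds go, it is also open whether the difference between the carbon-only and one-nitrogen rings would hold with a different substituent or outside the shared core.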